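From a fluorobenzyl to a chlorobenzyl on the oxadiazole arm

The compounds below may be only part of what the source reports. "The series", "measured", "known", "first", "only" and "open" are said of these compounds alone.

Measured so far:
Compound 1, `Cc1ccc(S(=O)(=O)N(Cc2nnc(Cc3ccc(N(C)C)cc3)o2)c2cccc(Cl)c2C)cc1`: 20 nM
Compound 2, `Cc1ccc(S(=O)(=O)N(Cc2nnc(Cc3ccc(F)cc3)o2)c2cccc(Cl)c2C)cc1`: 501 nM
Compound 3, `Cc1ccc(S(=O)(=O)N(Cc2nnc(Cc3cccc(F)c3)o2)c2cccc(Cl)c2C)cc1`: 501 nM

All three compounds share one core and differ only in the benzyl group hanging from the oxadiazole. In a functional assay on CHO cells for antagonist activity at prostaglandin E2 receptor EP1 subtype (Homo sapiens), read by FLIPR and calcium flux (a lower number here means a stronger inhibitor, a higher number a weaker inhibitor), compound 1 gives 20 nM, while compound 2 gives 501 nM and compound 3 gives 501 nM. Compound 3 thus stands level with compound 2 and, together with it, at the high end of the three numbers; the step of no change at the digits printed from compound 2 to compound 3 (within the scatter) shows that moving the fluorine around the ring made no difference here. The two large steps, a 25-fold higher number from compound 1 to compound 2 (1.40 log units; beyond the scatter) and a 25-fold higher number from compound 1 to compound 3 (1.40 log units; beyond the scatter), both concern the loss of the dimethylamino group and say nothing about what a different halogen does.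

Compound 4, `Cc1ccc(S(=O)(=O)N(Cc2nnc(Cc3ccccc3Cl)o2)c2cccc(Cl)c2C)cc1`, is the next member: 2-chlorophenyl in place of 3-fluorophenyl on a saturated chain carbon bound to an aromatic carbon. For the measured compounds named here, no measured step covers a chlorine on this ring, nor this arrangement of the substituent. Going by the values given here, the only pertinent step, from compound 2 to compound 3, was flat, so a small step, if any, is expected in this assay, and the expected step of a 1.3-fold lower number from compound 3 to compound 4 (0.10 log units; within the scatter) reflects that. Compound 4 is therefore estimated at 400 nM, within a range from 100 nM to 2000 nM.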

Compound 4, inhibition constant: 398 nM
For compound 4 the middle estimate is 1.0-fold (0.00 log units) above the measured one; low and high end bracket the measured number.
By their numbers in this assay, from the lowest: compound 1; then compounds 4, 2 and 3 (each within the scatter of the next).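

Changing the halogen and its place on the benzyl ring together leaves the number within the scatter in this assay: the step is a 1.3-fold lower number from compound 3 to compound 4 (0.10 log units; within the scatter), and against the other fluorinated compound it is a 1.3-fold lower number from compound 2 to compound 4 (0.10 log units; within the scatter). At this position, on a saturated chain carbon bound to an aromatic carbon, the 2-chlorophenyl, 3-fluorophenyl and 4-fluorophenyl groups therefore cannot be told apart, and a chlorine now joins the fluorines in this group of three. The 4-(dimethylamino)phenyl group remains the only one set apart, with a 20-fold higher number from compound 1 to compound 4 (1.30 log units; beyond the scatter), and no measurement shown here accounts for this gap or for the flatness among the halogenated compounds.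

Compound 4 changes the halogen and its ring place in a single step, so the compounds shown do not separate the two changes, which a 4-chlorophenyl group would begin to do against the 4-fluorophenyl group of compound 2. They also leave open whether the gap to compound 1 is specific to dimethylamino, or whether a primary amine or a methoxy group in the same place would give a number close to that of compound 1 or close to those of the halogenated compounds.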